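Compound 4: a trifluoromethoxy step from compound 1

This account rests on a few compounds, and the source may have more. Where it says the series, first, only, none or still open, it means among the compounds named here.

Measured so far in a functional assay on HO8910 cells (Homo sapiens) for inhibition, read by MTT assay, with a stated time of 24 h, tested at 0.1 ug/mL; a lower number here means less inhibition of growth, a higher number more inhibition of growth at the concentration tested:
- compound 1 `O=C(CCCCC(S)CCS)Nc1ccccc1`: 7.37%
- compound 2 `O=C(CCCCC(S)CCS)Nc1ccccc1Cl`: 6.11%
- compound 3 `O=C(CCCCC(S)CCS)Nc1cccc(Cl)c1`: "not active" (no number reported)

Compound 1 and compound 2 lie within the scatter of each other, so neither stands apart in this assay. Compound 3 is reported as "not active" (no number reported), without a number, and cannot be placed against them.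

Compound 4 `O=C(CCCCC(S)CCS)Nc1ccc(OC(F)(F)F)cc1` has not yet been measured. It differs from compound 1 by trifluoromethoxy in place of hydrogen on an aromatic carbon, para to a large group.

For the measured compounds named here, no measured step involves trifluoromethoxy or this position, so the evidence is indirect. Going by the values given here, the nearest guide is the one numerical step for a substituent placed on an aromatic carbon, a number 1.3 percentage points lower from compound 1 to compound 2 (within the scatter). That step is small, but it involves chloro, a different group, and offers only limited support. Compound 3, which also carries chloro on an aromatic carbon, adds no step size.

No step beyond the scatter is therefore expected, and the estimate is a number 0.4 percentage points lower from compound 1 to compound 4 (within the scatter). For compound 4 the expected value is 7%, with an estimated range of 0% to 16%.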

Compound 4, percent growth inhibition at one concentration: "not active" (no number reported)
The entry for compound 4 holds no number, so the estimate cannot be set against anything.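

In this assay, for the compounds shown here, compound 4 gives "not active" (no number reported), so no step from compound 1 to compound 4 can be read. No available evidence bears on this result. The compounds shown leave open how far compound 3 and compound 4, both without a number, lie from compound 1 in growth inhibition.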